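Moving the methoxy group on the aryl substituent

The source may hold more compounds than are shown below. What is called first, only, known or untested is meant among the compounds shown, and "the series" means these compounds.

Measured in a functional assay on MCF7 cells (Homo sapiens) for cytotoxicity, read by MTT assay, with a stated time of 96 h; a lower number here means a stronger inhibitor, a higher number a weaker inhibitor:
- compound 1 (`COc1cc(C(=O)c2cn(-c3ccccc3)cc2-c2cccc(Br)c2)cc(OC)c1OC`) gives 950 nM
- compound 2 (`COc1cc(C(=O)c2cn(-c3ccccc3)cc2-c2ccccc2[N+](=O)[O-])cc(OC)c1OC`) gives 49 nM
- compound 3 (`COc1ccccc1-c1cn(-c2ccccc2)cc1C(=O)c1cc(OC)c(OC)c(OC)c1`) gives 190 nM

Compound 3 holds the middle of these three numbers. The nearest neighbour is reached by a 3.9-fold higher number from compound 2 to compound 3 (0.59 log units; beyond the scatter) (a rise), and the furthest by a 5.0-fold lower number from compound 1 to compound 3 (0.70 log units; beyond the scatter) (a fall).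

Compound 4 (`COc1ccc(-c2cn(-c3ccccc3)cc2C(=O)c2cc(OC)c(OC)c(OC)c2)cc1`) is not yet measured. It keeps the shared core and differs from compound 3 in one group: 4-methoxyphenyl in place of 2-methoxyphenyl on an aromatic carbon.

Among the compounds with values here, no measured step moves a group around this phenyl ring, so the evidence is indirect. All three steps exchange the aryl group at this same place. Those steps are a 19-fold lower number from compound 1 to compound 2 (1.29 log units; beyond the scatter) (large), together with the modest two above, so this place is sensitive to change. The two compounds named with a 2-substituted phenyl have the lower numbers, while compound 1 with 3-bromophenyl has 950 nM as the highest. On three compounds this is only a weak hint that losing the 2-substitution may raise the number.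

In this assay a modest upward change is therefore expected, estimated as a 2.4-fold higher number from compound 3 to compound 4 (0.37 log units; beyond the scatter) with wide uncertainty. Compound 4 is estimated at 450 nM (expected range 100 nM to 1800 nM).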

Compound 4, half-maximal inhibitory concentration: 70 nM
Estimate against measurement, compound 4: 6.4-fold (0.81 log units) above; the whole stated range lies above it.
By their numbers in this assay, from the lowest: compounds 2 and 4 (each within the scatter of the next); then compound 3; then compound 1.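

In this assay, moving from 2-methoxyphenyl to 4-methoxyphenyl gives a 2.7-fold lower number from compound 3 to compound 4 (0.43 log units; beyond the scatter) and so lowers the number without any change in atom count, which shows that this place responds to where the methoxy sits on the phenyl ring and not only to which group is present. A group at the 2-position of this phenyl ring is not needed for a low number, and compound 4 goes against the earlier hint: a 1.4-fold higher number from compound 2 to compound 4 (0.15 log units; within the scatter) leaves the 4-methoxyphenyl and 2-nitrophenyl compounds unseparated, while a 14-fold lower number from compound 1 to compound 4 (1.13 log units; beyond the scatter) leaves the 3-bromophenyl compound apart from the other three. Nothing available accounts for the lower number with 4-methoxyphenyl.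

Within the data shown here, the high number of compound 1 cannot yet be assigned either to the bromine or to its place on the phenyl ring, as no pair here separates the two. Also open, on these data alone, is how this place would respond to an amine or a carboxylic acid in place of the methoxy, or to a longer chain such as ethoxy.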